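A few compounds are considered here, and "the series" means these few. Any claim that something is new, unique, unknown or untested is made for them only; others in the source may bear on it.

Four compounds share one core. Compound 1 has the structure `CO[C@@H]1[C@H](N(C)c2ncc(-c3c[nH]c4ccc(F)cc34)s2)C[C@H]2O[C@]1(C)n1c3ccccc3c3c4c(c5c6ccccc6n2c5c31)C(=O)NC4`, compound 2 the structure `CO[C@@H]1[C@H](N(C)c2ncc(-c3c[nH]c4ccc(Cl)cc34)s2)C[C@H]2O[C@]1(C)n1c3ccccc3c3c4c(c5c6ccccc6n2c5c31)C(=O)NC4`, compound 3 the structure `CO[C@@H]1[C@H](N(C)c2ncc(-c3c[nH]c4ccc(F)cc34)s2)C[C@H]2O[C@]1(C)n1c3ccccc3c3c4c(c5c6cc(Cl)ccc6n2c5c31)C(=O)NC4` and compound 4 the structure `CO[C@@H]1[C@H](N(C)c2ncc(-c3c[nH]c4ccc(Cl)cc34)s2)C[C@H]2O[C@]1(C)n1c3ccccc3c3c4c(c5c6cc(Cl)ccc6n2c5c31)C(=O)NC4`. In an ADME assay on PBMC cells (Homo sapiens) for cytotoxicity, read by CellTiter-Glo, with a stated time of 72 h (a higher number here means a weaker inhibitor, a lower number a stronger inhibitor), compound 1 gives > 10000 nM, which is a limit of the assay rather than a number. In this assay compound 2 gives > 10000 nM, also a limit. In this assay compound 3 gives > 10000 nM, again a limit. The change from compound 1 to compound 2 is chloro in place of fluoro on an aromatic carbon; its step, a step that the two limits leave unreadable from compound 1 to compound 2, cannot be read because both ends rest on (the limit of > 10000 nM in this assay, at which 3 of the 3 values shown sit). The two cores differ as chloro in place of hydrogen on an aromatic carbon, and the step that the two limits leave unreadable from compound 1 to compound 3 is equally unreadable because it too rests on (the limit of > 10000 nM in this assay, at which 3 of the 3 values shown sit). Compound 4 arises from compound 3 by the same change, (chloro in place of fluoro on an aromatic carbon), at the same place. With every measured value sitting at the limit, the expected step is a step that the limit leaves unreadable from compound 3 to compound 4, an expectation resting on compound 3 standing at the limit of > 10000 nM in this assay, at which 3 of the 3 values shown sit. Compound 4 is therefore estimated at 15000 nM. Its expected range runs from 8000 nM to 40000 nM.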

Compound 4, half-maximal inhibitory concentration: > 10000 nM
Compound 4: no number, only a limit (the forecaster's own chance of this, stated with the estimate: 85%); the middle value does not contradict the limit.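

In this assay compound 4 gives > 10000 nM, which is a limit of the assay and not a number. Neither the step from compound 3 to compound 4 nor that from compound 2 to compound 4 can be read, because both rest on a limit: the limit of > 10000 nM in this assay, at which 4 of the 4 values shown sit. The compounds shown leave open whether chloro in place of fluoro, or of hydrogen, changes the result in this assay at all.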